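From tert-butyl to 4-methylphenyl on the amide nitrogen

The compounds below may be only part of what the source reports. "The series", "measured", "known", "first", "only" and "open" are said of these compounds alone.

Compound 3 `C=CC1=C(C(=O)NC(C)(C)C)C(c2ccc(F)cc2)OC1` is one of three measured compounds that share a core. In a functional assay on SW480 cells (Homo sapiens) for cytotoxicity, read by MTT assay, with a stated time of 24 h (a lower number here means a stronger inhibitor, a higher number a weaker inhibitor), compound 3 gives only a limit, > 100000 nM. Compound 1 `C=CC1=C(C(=O)Nc2ccccc2OC)C(c2ccc(F)cc2)OC1` likewise gives a limit in this assay, > 100000 nM. Compound 2 `C=CC1=C(C(=O)NCC(C)C)C(c2ccc(F)cc2)OC1` gives in this assay the limit > 100000 nM. The steps a step that the two limits leave unreadable from compound 1 to compound 2, a step that the two limits leave unreadable from compound 1 to compound 3 and a step that the two limits leave unreadable from compound 2 to compound 3 are thus all unreadable, as the limit of > 100000 nM in this assay, at which 3 of the 3 values shown sit, records. Compound 4 `C=CC1=C(C(=O)Nc2ccc(C)cc2)C(c2ccc(F)cc2)OC1` differs from compound 3 by 4-methylphenyl in place of tert-butyl on an amide-type nitrogen. Among the measured compounds shown here, no measured step gives a readable size for this change; the nearest comparison, between compound 1 and compound 3, has both ends at the limit. Compound 4 is therefore expected to remain at the limit, with an estimated 150000 nM (range 50000 nM to 500000 nM) and an expected step that the limit leaves unreadable from compound 3 to compound 4 of no meaningful size.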

Compound 4, half-maximal inhibitory concentration: > 100000 nM
Compound 4 was reported as a limit; the forecaster's own chance of this, stated with the estimate: 85%; the middle value does not contradict the limit.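

No step from compound 1, compound 2 or compound 3 to compound 4 can be read in this assay, because all four compounds sit at one limit: the limit of > 100000 nM in this assay, at which 4 of the 4 values shown sit.

The compounds shown leave open which group on the amide-type nitrogen, if any, would give a readable value in this assay.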